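The source may report more compounds than this note shows. Statements on the series, on what has been measured and on what is new or still open speak of the compounds shown alone.

Measured in a functional assay on CHO cells for antagonist activity at growth hormone secretagogue receptor type 1 (Homo sapiens); on this read-out higher numbers stand for weaker inhibition and lower numbers for stronger inhibition:
compound 1 `CCc1ccc(Cn2c(CCc3ccccc3)nnc2[C@H](NC(=O)c2ccccn2)c2c[nH]c3ccccc23)cc1` gives 513 nM
compound 2 `COc1ccc(Cn2c(CCc3ccccc3)nnc2[C@H](NC(=O)c2ccccn2)c2c[nH]c3ccccc23)cc1` gives 12 nM
compound 3 `CCc1ccc(Cn2c(CCc3ccccc3)nnc2[C@H](NC(=O)Cc2ccccn2)c2c[nH]c3ccccc23)cc1` gives 124 nM

Compound 1 and compound 2 share a core and differ in one place: methoxy in place of ethyl on an aromatic carbon. This single change made a large step, a 43-fold lower number from compound 1 to compound 2 (1.63 log units; beyond the scatter).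

The core of compound 3 differs from that of compound 1 in the group on the carbonyl carbon: (pyridin-2-yl)methyl in place of pyridin-2-yl on a carbonyl carbon. That step was modest, a 4.1-fold lower number from compound 1 to compound 3 (0.62 log units; beyond the scatter), and compound 3 stands between compound 1 and compound 2 in this assay, with compound 2 the lowest of the three numbers.

Compound 4 `COc1ccc(Cn2c(CCc3ccccc3)nnc2[C@H](NC(=O)Cc2ccccn2)c2c[nH]c3ccccc23)cc1` has not yet been measured in this assay. It relates to compound 3 as compound 2 relates to compound 1: methoxy in place of ethyl on an aromatic carbon. The place of the change reads the same way in both pairs, so it is the same change, here carried out on the core that bears the (pyridin-2-yl)methyl group. Among the measured compounds shown here, the only measure of this change is the one step from compound 1 to compound 2, so the expectation rests on a single pair and on the assumption that the other core does not alter its effect. For the measured compounds named here, a step of roughly that size, slightly tempered since only one example supports it, is expected from compound 3 to compound 4, a 25-fold lower number from compound 3 to compound 4 (1.39 log units; beyond the scatter), because the same change gave a 43-fold lower number from compound 1 to compound 2 (1.63 log units; beyond the scatter). Compound 4 is therefore estimated at 5 nM in this assay, with a range from 1.5 nM to 20 nM.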

Compound 4, antagonist equilibrium constant: 6 nM
The estimate for compound 4 lay 1.2-fold (0.08 log units) below the measured number; measured number inside the range.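

In this assay, among the compounds shown here, methoxy in place of ethyl on an aromatic carbon carried over from the core of compound 1 to the core of compound 3, with a 21-fold lower number from compound 3 to compound 4 (1.32 log units; beyond the scatter), and the size of the step held across the two cores: the same change on two cores in this assay, a 43-fold lower number (1.63 log units; beyond the scatter) from compound 1 to compound 2 and a 21-fold lower number (1.32 log units; beyond the scatter) from compound 3 to compound 4, 2.1-fold (0.32 log units) apart, within the scatter of two such steps The change from pyridin-2-yl to (pyridin-2-yl)methyl on the carbonyl carbon gives a 2.0-fold lower number from compound 2 to compound 4 (0.30 log units; within the scatter), so on the methoxy core it cannot be told apart from the scatter, although the step on the ethyl core lies beyond it; even so, the two steps do not differ beyond what two such steps can scatter: the same change on two cores in this assay, a 4.1-fold lower number (0.62 log units; beyond the scatter) from compound 1 to compound 3 and a 2.0-fold lower number (0.30 log units; within the scatter) from compound 2 to compound 4, 2.1-fold (0.32 log units) apart, within the scatter of two such steps These four compounds give only one pair of cores for each change, so they show additivity within this small set, but not that either change would carry to other cores, and they do not explain why either change has the effect seen.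

Still open, as far as these compounds go, is whether an ethoxy group, a chlorine or a hydroxyl on the same aromatic carbon would follow methoxy or ethyl. Also open, from the compounds shown here alone, is how a longer chain between the carbonyl carbon and the pyridine ring, or an amine in place of the pyridine ring, would read in this assay.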